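Swapping a Pyridine Ring Back for Phenyl

The source may report more compounds than this note shows. Statements on the series, on what has been measured and on what is new or still open speak of the compounds shown alone.

Compound 1 `C[C@@H](Sc1nc2c(cnn2C)c(=O)n1-c1ccccc1)c1ccccc1`: 40 nM
Compound 2 `C#Cc1ccc(-n2c(SC(C)c3ccccc3)nc3c(cnn3C)c2=O)cc1`: 800 nM
Compound 3 `CC(Sc1nc2c(cnn2C)c(=O)n1-c1ccccc1)c1cccnc1`: 89 nM

In an assay on isolated protein for inhibition of retinal dehydrogenase 2 (Homo sapiens) (a lower number here means a stronger inhibitor, a higher number a weaker inhibitor), compound 3 stands second highest of the three numbers, nearest to compound 1 and furthest from compound 2. Compound 4 `CC(Sc1nc2c(cnn2C)c(=O)n1-c1ccccc1)c1ccccc1` differs from compound 3 in one place: phenyl in place of pyridin-3-yl on a saturated chain carbon bound to a saturated chain carbon and a sulfur. Within the data shown here, the only measured step that bears on this is a 2.2-fold higher number from compound 1 to compound 3 (0.35 log units; beyond the scatter), which is the same change run the other way; compound 4 shares all of compound 1 apart from the defined handedness at the chain carbon in compound 1. Reversing that step, compound 4 is expected to give a lower number than compound 3, by a 1.6-fold lower number from compound 3 to compound 4 (0.21 log units; within the scatter). Compound 4 is therefore estimated at 55 nM, with a range of 25 nM to 130 nM.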

Compound 4, half-maximal inhibitory concentration: 110 nM
Estimate against measurement, compound 4: 2.0-fold (0.30 log units) below, within the range that was stated.
By their numbers in this assay, from the lowest: compound 1; then compounds 3 and 4 (each within the scatter of the next); then compound 2.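

In this assay a step of a 1.2-fold higher number from compound 3 to compound 4 (0.09 log units; within the scatter) shows that phenyl and pyridin-3-yl cannot be told apart at this chain carbon when neither compound has a drawn configuration. Hydrogen in place of ethynyl on an aromatic carbon gives a 7.3-fold lower number from compound 2 to compound 4 (0.86 log units; beyond the scatter) and so remains a clear gain in strength. The remaining gap of a 2.8-fold higher number from compound 1 to compound 4 (0.44 log units; beyond the scatter) involves no change of atoms or bonds and points to a different source: the fact that one of compounds 1 and 4 is drawn with a defined configuration and the other without, at the place where they differ.

Still open, as far as these compounds go, is how the two separate mirror-image forms of compound 4 compare with each other. Also open, from the compounds shown here alone, is whether an amine in place of pyridin-3-yl would stay this close.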